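This account rests on a few compounds, and the source may have more. Where it says the series, first, only, none or still open, it means among the compounds named here.

Two compounds of this series have numbers in an in vitro functional assay on HEK285-7 cells for antagonist activity at prostaglandin D2 receptor 2 (Homo sapiens), read by BRET and beta-arrestin recruitment; a higher number here means a larger maximal response, a lower number a smaller maximal response. Compound 1 `COc1ccc(OC)c(-c2nc(C(c3ccccc3)c3ccccc3)sc2CC(=O)O)c1` gives 80%. Compound 2 `CCC(c1ccccc1)c1nc(-c2ccc(Cl)cc2)c(CC(=O)O)s1` gives 50%, the lowest of the two and beyond the scatter from compound 1. Compound 3 `O=C(O)Cc1sc(C(c2ccccc2)c2ccccn2)nc1-c1ccc(Cl)cc1` has not been measured. It differs from compound 2 by pyridin-2-yl in place of ethyl on a saturated chain carbon bound to two aromatic carbons, so that the saturated chain carbon again carries two aromatic rings, as in compound 1. The expectation is a moderate rise, a number 15 percentage points higher from compound 2 to compound 3 (beyond the scatter), near the edge of the scatter rather than clearly beyond it. Compound 3 is estimated at 65%, with a range from 45% to 85%.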

Compound 3, largest response reached (reported as efficacy), in percent of the reference or control that the assay uses: 55%
Estimate against measurement, compound 3: 10 percentage points above; the range from low to high includes it.
By their numbers in this assay, from the lowest: compounds 2 and 3 (each within the scatter of the next); then compound 1.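

In this assay, pyridin-2-yl in place of ethyl on a saturated chain carbon bound to two aromatic carbons gives a number 5 percentage points higher from compound 2 to compound 3 (within the scatter), so this assay does not tell the two groups apart at this position. A second aromatic ring on that carbon, as in compound 1, therefore does not by itself separate compound 3 from compound 2. No measured evidence bears on this result.

Open, from the compounds shown here alone, is whether an amine on that carbon, or a longer chain in place of ethyl, would move the number beyond the scatter. Compound 1 differs from compound 3 in more than one place, so the values of that pair assign nothing to a single group.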